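Trifluoromethyl in Place of Methoxy on a Level Series

A few compounds are considered here, and "the series" means these few. Any claim that something is new, unique, unknown or untested is made for them only; others in the source may bear on it.

In an ADME assay on HEK293 cells (Homo sapiens) for cytotoxicity, read by CellTiter-Glo, with a stated time of 72 h (a higher number here means that more compound is needed for the effect, a lower number that less compound is needed), compound 1 `CC1=C2CC(C)(C)/C=C/[C@H](OC(=S)Sc3ccccc3)/C(C)=C\C3=C[C@H](C)C[C@]3(O2)C1=O` gives 26000 nM, compound 2 `C/C1=C/C2=C[C@H](C)C[C@@]23O[C@]2(CC(C)(C)[C@@H](Br)[C@@H]2C1=O)[C@](C)(Br)C3=O` gives 26000 nM, and compound 3 `COc1ccc(/C2=C\C(=O)/C(C)=C\C3=C[C@H](C)C[C@@]34OC(=C(C)C4=O)CC2(C)C)cc1` gives 26000 nM, so compound 3 stands level with the other two. Compound 4 `CC1=C2CC(C)(C)/C(c3ccc(C(F)(F)F)cc3)=C/C(=O)/C(C)=C\C3=C[C@H](C)C[C@]3(O2)C1=O` has trifluoromethyl in place of methoxy on an aromatic carbon, para to a large group (trifluoromethyl in place of methoxy on an aromatic carbon). Among the measured compounds shown here, no measured pair isolates a single change of this kind. The three measured compounds carry different groups on the shared core, yet their values coincide. A change beyond the scatter in this assay is therefore not expected, and neither direction is favoured. The expected change is no change at the digits printed from compound 3 to compound 4 (within the scatter). For compound 4, the estimated value is 26000 nM, with an expected range from 12000 nM to 45000 nM.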

Compound 4, half-maximal effective concentration: 26000 nM
Compound 4: the middle estimate sits on the measured number at the digits printed, within the range that was stated.
By their numbers in this assay, from the lowest: compounds 1, 2, 3 and 4 (each within the scatter of the next).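

In this assay, among the compounds shown here, the step of no change at the digits printed from compound 3 to compound 4 (within the scatter) is the first comparison that differs in one place only, which the earlier compounds could not offer. It shows that, on this aromatic carbon, 4-methoxyphenyl and 4-(trifluoromethyl)phenyl cannot be told apart in this assay. No supporting measurement is available to explain this result. The compounds shown leave open whether an amine or a carboxylic acid on this same carbon would also read level. They also leave open whether any group here can move the value away from the shared number.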